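The source may report more compounds than this note shows. Statements on the series, on what has been measured and on what is new or still open speak of the compounds shown alone.

Measured compounds in a functional assay on SW-620 cells (Homo sapiens) for inhibition, read by MTT assay, with a stated time of 72 h; a lower number here means a stronger inhibitor, a higher number a weaker inhibitor:
- compound 1, `CCCCc1ccc(-c2cn(Cc3cc(=O)oc4cc(O)ccc34)nn2)cc1`: 49200 nM
- compound 2, `O=c1cc(Cn2cc(-n3ccc4cc(I)ccc43)nn2)c2ccc(O)cc2o1`: 34300 nM

Both numbers sit in the same high region. Compound 2 shows the lower figure of the two, yet its gap to compound 1 is within the scatter, so the two compounds cannot be told apart on these data.

Compound 3, `Cc1ccc2c(Cn3cc(-n4ccc5cc(I)ccc54)nn3)cc(=O)oc2c1`, differs from compound 2 by methyl in place of hydroxy on an aromatic carbon. Within the data shown here, no measured pair shows this kind of exchange, so its effect in this assay is unknown. With both numbers so close, the change is expected to leave the figure within the scatter, a step of a 1.2-fold higher number from compound 2 to compound 3 (0.07 log units; within the scatter) of no clear direction. Compound 3 is therefore estimated at 40000 nM, ranging from 15000 nM to 110000 nM.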

Compound 3, half-maximal inhibitory concentration: 70000 nM
Compound 3: middle estimate off by 1.8-fold (0.24 log units), on the low side; low and high end bracket the measured number.
By their numbers in this assay, from the lowest: compounds 2, 1 and 3 (each within the scatter of the next, the first and the last beyond it).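

In this assay, among these compounds, methyl in place of hydroxy on this aromatic carbon gives a 2.0-fold higher number from compound 2 to compound 3 (0.31 log units; beyond the scatter), the first step that can be read, and a modest one. The position is therefore not indifferent to this exchange: the number rises when the hydroxy, with its hydrogen-bond donor and acceptor, leaves. No measured data on hand explain the step.

From the compounds shown here alone, whether the step follows from losing hydroxy or from gaining methyl remains open. An amine or a methoxy group on the same aromatic carbon would bear on that question.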